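Sulfonamide to Acetamide on the Side-Chain Nitrogen

The compounds below may be only part of what the source reports. "The series", "measured", "known", "first", "only" and "open" are said of these compounds alone.

Compound 3 `CCS(=O)(=O)NCc1cncc(N2C(=O)c3ccc(Cl)cc3C2(C)C)c1` gives 92 nM in an assay on cells for inhibition of cytochrome P450 11B2, mitochondrial (Homo sapiens), read by HTRF (on this read-out lower numbers stand for stronger inhibition and higher numbers for weaker inhibition), the second highest of the three numbers. Compound 1 `CC(=O)N[C@@H]1CCCc2c1cncc2N1C(=O)c2ccc(Cl)cc2[C@H]1C` gives 130 nM, within the scatter of compound 3, and compound 2 `CC(=O)N1CC[C@H](Oc2cncc(N3C(=O)c4ccc(Cl)cc4C3(C)C)c2)C1` gives 7 nM. Going by the values given here, the one measured step, a 13-fold higher number from compound 2 to compound 3 (1.12 log units; beyond the scatter), exchanged whole side chains on the shared core. Compound 4 `CC(=O)NCc1cncc(N2C(=O)c3ccc(Cl)cc3C2(C)C)c1` differs from compound 3 by acetyl in place of ethylsulfonyl on an amine nitrogen. Among the compounds with values here, no measured step swaps these two groups on the same nitrogen, so the expectation rests on the acetamido-bearing compound 1 and compound 3 lying within the scatter of each other. The analyst therefore expects for compound 4 a step of a 1.2-fold higher number from compound 3 to compound 4 (0.08 log units; within the scatter), within the scatter. Compound 4 is estimated at 110 nM, ranging from 35 nM to 350 nM.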

Compound 4, half-maximal inhibitory concentration: 59 nM
For compound 4 the middle estimate is 1.9-fold (0.27 log units) above the measured one, and the stated range covers the measured number.
By their numbers in this assay, from the lowest: compound 2; then compounds 4, 3 and 1 (each within the scatter of the next, the first and the last beyond it).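

In this assay the direct exchange on the amine nitrogen stays within the scatter (a 1.6-fold lower number from compound 3 to compound 4 (0.19 log units; within the scatter)), so acetyl and ethylsulfonyl are not told apart on this side chain. The acetamidomethyl chain still leaves a gap to the side chain of compound 2 (an 8.4-fold higher number from compound 2 to compound 4 (0.93 log units; beyond the scatter)), so replacing ethylsulfonyl with acetyl does not close that gap. No evidence is available on what lies behind either step. From the compounds shown here alone, whether methylsulfonyl or a longer acyl chain such as butanoyl on the same nitrogen would read differently stays open. So does which part of the side chain of compound 2 accounts for its lower number.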